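The compounds below may be only part of what the source reports. "The series", "measured", "known", "first", "only" and "open" are said of these compounds alone.

Measured compounds:
- compound 1, `O=C(Nc1cccc(-c2nc(-c3ccc(NC(=O)c4cccnc4)cc3Cl)no2)c1)Nc1cccc(C(F)(F)F)c1`: 1900 nM
- compound 2, `O=C(Nc1cccc(-c2nc(-c3ccc(NC(=O)c4cccnc4)cc3Cl)no2)c1)Nc1cc(C(F)(F)F)cc(C(F)(F)F)c1`: 1900 nM

In a functional assay on MDA-MB-231 cells (Homo sapiens) for antiproliferative activity, read by MTT assay, with a stated time of 72 h (a higher number here means a weaker inhibitor, a lower number a stronger inhibitor), compound 1 gives 1900 nM. Compound 2 gives 1900 nM in this assay, so the step of no change at the digits printed from compound 1 to compound 2 (within the scatter). On these numbers compound 1 stands level with compound 2, and nothing in the pair separates them.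

Compound 3, `O=C(Nc1cccc(-c2nc(-c3ccc(NC(=O)c4cccnc4)cc3Cl)no2)c1)Nc1ccc(NC(=O)C2CC2)c(C(F)(F)F)c1`, is obtained from compound 1 by the change ((cyclopropylcarbonyl)amino in place of hydrogen on an aromatic carbon). Within the data shown here, the one measured step that bears on this change is the step from compound 1 to compound 2, which also adds a group to the same terminal aromatic ring of the urea, and that step was no change at the digits printed from compound 1 to compound 2 (within the scatter). Among the measured compounds shown here, no measured step tests the entry of a group of this kind, one that brings a hydrogen-bond donor and acceptor and a three-membered ring, so the expectation rests on a single precedent.

Compound 3 is therefore expected to show a step of a 1.3-fold lower number from compound 1 to compound 3 (0.10 log units; within the scatter) in this assay, small and not clearly beyond the scatter in either direction. The estimate for compound 3 is 1500 nM, with a range from 450 nM to 5000 nM.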

Compound 3, half-maximal inhibitory concentration: 200 nM
Compound 3: middle estimate off by 7.5-fold (0.88 log units), on the high side; measured number below the stated range.
By their numbers in this assay, from the lowest: compound 3; then compounds 1 and 2 (each within the scatter of the next).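

In this assay, (cyclopropylcarbonyl)amino in place of hydrogen on an aromatic carbon, ortho to a trifluoromethyl group and para to a large group, gives a 9.5-fold lower number from compound 1 to compound 3 (0.98 log units; beyond the scatter) and so shows that the number can respond to a substituent at this position on this ring. The earlier trifluoromethyl change gave no change at the digits printed from compound 1 to compound 2 (within the scatter) and so offered no sign of this; of the two steps shown, only the (cyclopropylcarbonyl)amino change lies beyond the scatter. Nothing measured here accounts for the lower number, and no separate data bear on how this group acts on these cells.

The compounds shown leave open whether the step belongs to the whole (cyclopropylcarbonyl)amino group or to a part of it, a question that acetylamino or a plain amino group at the same position would address, as would a cyclobutylcarbonylamino group for the size of the ring. They also leave open whether the neighbouring trifluoromethyl group matters to the step, which a chlorine atom or a methyl group in its place would test.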